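Swapping a Carboxypiperidine Arm for an Aldehyde

The source may report more compounds than this note shows. Statements on the series, on what has been measured and on what is new or still open speak of the compounds shown alone.

Compound 2 `COc1ccc(/C=C\c2cc(OC)c(OC)c(OC)c2)cc1OCc1ccc(CN2CCCC[C@H]2C(=O)O)cc1` stands only at a limit: in a functional assay on HepG2 cells (Homo sapiens) for antiproliferative activity, read by CCK-8 assay, with a stated time of 48 h (a lower number here means a stronger inhibitor, a higher number a weaker inhibitor), compound 2 gives > 10000 nM, which is a limit of the assay rather than a number. Compound 1 `COc1ccc(/C=C\c2cc(OC)c(OC)c(OC)c2)cc1OCc1ccc(CN[C@H](C(=O)O)[C@H](C)O)cc1` likewise gives > 10000 nM, also a limit. Compound 3 `COc1ccc(/C=C\c2cc(OC)c(OC)c(OC)c2)cc1OCc1ccc(CN2CC[C@@H](C(=O)O)C2)cc1` gives 2300 nM, a measured number. Between these three there is a step that the two limits leave unreadable from compound 1 to compound 2, whereas an at least 4.3-fold lower number from compound 2 to compound 3 (0.63 log units; beyond the scatter) and an at least 4.3-fold lower number from compound 1 to compound 3 (0.63 log units; beyond the scatter) show that altering the group on the saturated chain carbon bound to an aromatic carbon moves the number well beyond the scatter. Compound 4 `COc1ccc(/C=C\c2cc(OC)c(OC)c(OC)c2)cc1OCc1ccc(C=O)cc1` differs from compound 2 by formyl in place of (2-carboxypiperidin-1-yl)methyl on an aromatic carbon. Among the compounds with values here, no measured step removes the whole carboxy-bearing ring, so the direction is uncertain. Compound 4 is expected to give about 2500 nM, within 300 nM to 10000 nM. That estimate means an at least 4.0-fold lower number from compound 2 to compound 4 (0.60 log units; beyond the scatter).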

Compound 4, half-maximal inhibitory concentration: 800 nM
Beside the measured number, compound 4's estimate is 3.1-fold (0.49 log units) above it; low and high end bracket the measured number.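

Replacing the carboxy-bearing arm on this aromatic carbon with a formyl group gives large steps, an at least 12-fold lower number from compound 2 to compound 4 (1.09 log units; beyond the scatter) and an at least 12-fold lower number from compound 1 to compound 4 (1.09 log units; beyond the scatter). Even the one arm with a measured value is surpassed, a 2.9-fold lower number from compound 3 to compound 4 (0.46 log units; beyond the scatter), so among these compounds, none of the three arms beats plain formyl. The first two steps start from an assay limit rather than a number, so their full size cannot be read: the limit of > 10000 nM in this assay, at which 2 of the 4 values shown sit.

The compounds shown leave open whether the gain needs the formyl itself. A hydroxymethyl group, or a piperidin-1-ylmethyl arm without the carboxylic acid, could separate these possibilities.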